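Chloro substitution on the benzyl group of compound 3

The compounds below may be only part of what the source reports. "The series", "measured", "known", "first", "only" and "open" are said of these compounds alone.

Measured so far in an assay on HEK293 cells for agonist activity at Toll-like receptor 8 (Homo sapiens), read by a luciferase reporter, with a stated time of 6 h; on this read-out higher numbers stand for an effect only at larger amounts of compound and lower numbers for an effect already at smaller amounts:
compound 1 `CCCCNc1nc(N)nc2c1CN(Cc1ccccc1)CC2` gives 0.06 uM
compound 2 `CCCCNc1nc(N)nc2c1CNCC2` gives 7.2 uM
compound 3 `CCCCNc1nc(N)nc2c1CN(Cc1ccccc1Cl)CC2` gives 0.05 uM

Compound 3 stands at the low end of the three numbers, with compound 1 alongside it: the step of a 1.2-fold lower number from compound 1 to compound 3 (0.08 log units; within the scatter) is within the scatter, so the two are not separated. Compound 2, which carries hydrogen on the ring amine nitrogen, lies far apart from both; the steps of a 120-fold higher number from compound 1 to compound 2 (2.08 log units; beyond the scatter) and a 140-fold lower number from compound 2 to compound 3 (2.16 log units; beyond the scatter) show that the benzyl group on that nitrogen carries nearly all of the difference seen in the series, while the chloro on the benzyl ring adds nothing that can be told from noise.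

Compound 4 `CCCCNc1nc(N)nc2c1CN(Cc1c(Cl)cccc1Cl)CC2` differs from compound 3 by chloro in place of hydrogen on an aromatic carbon. For the measured compounds named here, the only measured step that bears on this change is a 1.2-fold lower number from compound 1 to compound 3 (0.08 log units; within the scatter), the first chloro in place of hydrogen on the same ring, and it was within the scatter. Going by the values given here, no measured pair speaks to a second chloro. On that basis no step beyond the scatter is expected in this assay for compound 4, in either direction: the expected step is no change at the digits printed from compound 3 to compound 4 (within the scatter).

Compound 4 is therefore estimated at 0.05 uM, with a range of 0.02 uM to 0.15 uM.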

Compound 4, minimum effective concentration: 0.14 uM
For compound 4 the middle estimate is 2.8-fold (0.45 log units) below the measured one, and the stated range covers the measured number.
By their numbers in this assay, from the lowest: compounds 3 and 1 (each within the scatter of the next); then compound 4; then compound 2.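

In this assay, for the compounds shown here, the second chloro is the first change on this ring that registers: a 2.8-fold higher number from compound 3 to compound 4 (0.45 log units; beyond the scatter) lies beyond the scatter, whereas the first chloro, in a 1.2-fold lower number from compound 1 to compound 3 (0.08 log units; within the scatter) on the same ring, does not, so the two chloro substitutions do not read alike. The 2,6-dichlorophenyl group also separates from plain phenyl in a 2.3-fold higher number from compound 1 to compound 4 (0.37 log units; beyond the scatter) and this modest step stays small beside the removal of the whole benzyl group in a 120-fold higher number from compound 1 to compound 2 (2.08 log units; beyond the scatter), so the ring tolerates the added chloro with a measurable but limited shift toward larger amounts of compound. No measurement on hand bears on why the number moves.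

The compounds shown leave open whether the shift belongs to chloro itself or to any group at this place on the ring, a question that a 2,6-difluorophenyl or 2,6-dimethylphenyl group would address. Also open, from the compounds shown here alone, is whether a single chloro placed meta to the large group, or a methoxy group there, would leave the number within the scatter of compound 1 or move it as the second chloro does.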